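A few compounds are considered here, and "the series" means these few. Any claim that something is new, unique, unknown or untested is made for them only; others in the source may bear on it.

Measured compounds:
compound 1, `CC1=C(/C=C/C(=O)/C=C/c2cccc(C(F)(F)F)c2)C(C)(C)CCC1`, 7700 nM
compound 2, `CC1=C(/C=C/C(=O)/C=C/c2cccc([N+](=O)[O-])c2)C(C)(C)CCC1`, 10000 nM

In a functional assay on PC-3 cells (Homo sapiens) for cytotoxicity, read by MTT assay, with a stated time of 72 h (on this read-out higher numbers stand for weaker inhibition and lower numbers for stronger inhibition), compound 2 stands at the highest of the two numbers; its nearest neighbour is compound 1, and the step between them, a 1.3-fold higher number from compound 1 to compound 2 (0.11 log units; within the scatter), lies within the usual scatter of repeated measurements, so the two cannot be told apart. Compound 3, `CC1=C(/C=C/C(=O)/C=C/c2cc([N+](=O)[O-])ccc2Cl)C(C)(C)CCC1`, has not yet been measured. It differs from compound 2 in one place: chloro in place of hydrogen on an aromatic carbon. Going by the values given here, the only measured step, from compound 1 to compound 2, concerns a different exchange, nitro for trifluoromethyl, and gives no guidance on adding a chloro group. Among the compounds with values here, no comparable step is available, so compound 3 is expected to stay close to compound 2, a step of no change at the digits printed from compound 2 to compound 3 (within the scatter), with no change beyond the scatter. The estimate for compound 3 in this assay is 10000 nM, with a range from 4000 nM to 25000 nM.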

Compound 3, half-maximal inhibitory concentration: 18900 nM
Estimate against measurement, compound 3: 1.9-fold (0.28 log units) below; the range from low to high includes it.
By their numbers in this assay, from the lowest: compounds 1, 2 and 3 (each within the scatter of the next, the first and the last beyond it).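

In this assay, going by these compounds alone, the step of a 1.9-fold higher number from compound 2 to compound 3 (0.28 log units; within the scatter) is the only reading so far for chloro in place of hydrogen on this aromatic carbon, ortho to a large group and para to a nitro group. It shows that this position can carry a chloro group without a change that can be told from the scatter, so compound 2 and compound 3 cannot be separated on this read-out. No other measurement here bears on this result, so it offers no explanation for the number.

On these data alone, whether an amine, a methoxy group or a carboxylic acid at this same carbon would give a step beyond the scatter remains open. As far as these compounds go, it is also open whether chloro would give a similar step with trifluoromethyl in place of the nitro group.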